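The compounds below may be only part of what the source reports. "The series", "measured", "known", "first", "only" and "open" are said of these compounds alone.

Working notes on the series. Compound 1 `O=C(/C=C/c1ccc2c(c1)B(O)OC2)c1ccco1` carries furan-2-yl on the carbonyl carbon. In an ADME assay on L929 cells (Mus musculus) for cytotoxicity, read by resazurin assay, with a stated time of 72 h (a higher number here means a weaker inhibitor, a lower number a stronger inhibitor), compound 1 gives only a limit, > 10 ug/mL. Compound 2 `O=C(/C=C/c1ccc2c(c1)B(O)OC2)c1ccc(O)c(O)c1` likewise gives only a limit in this assay, > 10 ug/mL. Among the measured compounds shown here, compound 3 `COc1cc(C(=O)/C=C/c2ccc3c(c2)B(O)OC3)ccc1N` gives 1.45 ug/mL in this assay, the one value that is a number. Compound 1 sits at the limit of > 10 ug/mL in this assay, at which 2 of the 3 values shown sit, so its place among the measured compounds is not fixed. Compound 4 `O=C(/C=C/c1ccc2c(c1)B(O)OC2)c1ccccc1F` is not yet measured; it differs from compound 1 by 2-fluorophenyl in place of furan-2-yl on a carbonyl carbon. For the measured compounds named here, no step between measured compounds is known here, and from a limit only a small move, in either direction or none beyond the scatter, is expected in this assay. Compound 4 is expected at 12 ug/mL, in the range 4 ug/mL to 35 ug/mL. The step from compound 1 to compound 4 is estimated as a step that the limit leaves unreadable from compound 1 to compound 4.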

Compound 4, half-maximal inhibitory concentration: > 10 ug/mL
Compound 4: a limit, no number; the forecaster's own chance of this, stated with the estimate: 60%; the middle value does not contradict the limit.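

Compound 1 and compound 4 both give only a limit in this assay, so no step can be read between them: the limit of > 10 ug/mL in this assay, at which 3 of the 4 values shown sit. The compounds shown leave open where compound 1, compound 2 and compound 4 truly stand in this assay.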